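A few compounds are considered here, and "the series" means these few. Any claim that something is new, unique, unknown or untested is made for them only; others in the source may bear on it.

Compound 1 `CCCNC(=O)c1cc(Oc2ccc(NC(=O)c3cc4cccnc4n(-c4ccccc4F)c3=O)cc2)ccn1` and compound 2 `CCCNC(=O)c1cc(Oc2ccc(NC(=O)c3cc4cccnc4n(-c4ccc(Br)cc4)c3=O)cc2)ccn1` share one core and differ only in the group carried on an aromatic nitrogen. In a functional assay on HT-29 cells (Homo sapiens) for antiproliferative activity, read by MTT assay, with a stated time of 72 h (on this read-out higher numbers stand for weaker inhibition and lower numbers for stronger inhibition), compound 1 gives 200 nM, and compound 2 gives 530 nM. Among the compounds with values here, the single change between them, a 4-bromophenyl in place of a 2-fluorophenyl on that nitrogen, brought a 2.7-fold higher number from compound 1 to compound 2 (0.42 log units; beyond the scatter). Among the two numbers measured so far, compound 2 thus holds the higher one, with compound 1 as its only neighbour.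

Within the data shown here, compound 3 `CCCNC(=O)c1cc(Oc2ccc(NC(=O)c3cc4cccnc4n(-c4ccc(F)c(Cl)c4)c3=O)cc2)ccn1` keeps everything else and alters only that same group: 3-chloro-4-fluorophenyl in place of 4-bromophenyl on an aromatic nitrogen. Among the measured compounds shown here, only one measured step touches this position, namely a 2.7-fold higher number from compound 1 to compound 2 (0.42 log units; beyond the scatter), and it compared a 2-fluorophenyl with a 4-bromophenyl rather than with a 3-chloro-4-fluorophenyl, so it offers limited guidance. Since compound 3 still carries a phenyl bearing halogens on that nitrogen, no step beyond the scatter is expected in this assay, and a 1.3-fold lower number from compound 2 to compound 3 (0.10 log units; within the scatter) is the estimated move. Compound 3 is therefore expected to give about 420 nM in this assay, with a likely range from 150 nM to 1200 nM.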

Compound 3, half-maximal inhibitory concentration: 920 nM
Beside the measured number, compound 3's estimate is 2.2-fold (0.34 log units) below it; measured number inside the range.
By their numbers in this assay, from the lowest: compound 1; then compounds 2 and 3 (each within the scatter of the next).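

In this assay, 3-chloro-4-fluorophenyl in place of 4-bromophenyl gives a 1.7-fold higher number from compound 2 to compound 3 (0.24 log units; within the scatter), so this read-out does not separate these two halogen-bearing phenyl groups, even though one carries a single halogen and the other carries two. Measured against the 2-fluorophenyl, the same 3-chloro-4-fluorophenyl gives a 4.6-fold higher number from compound 1 to compound 3 (0.66 log units; beyond the scatter), which is a second step beyond the scatter from compound 1 and makes compound 1 the only one of the three that stands apart, with the lowest number. Nothing available explains why the 2-fluorophenyl differs from the other two groups.

The phenyl groups in compound 1, compound 2 and compound 3 differ both in which halogens they carry and in where those halogens sit, so these three compounds cannot show which of the two matters here. An unsubstituted phenyl, a 4-fluorophenyl and a 2-chlorophenyl on the same nitrogen would each separate these questions, and a methyl there would test whether a phenyl ring is needed at all.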